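The source may report more compounds than this note shows. Statements on the series, on what has been measured and on what is new or still open speak of the compounds shown alone.

The series shares one core, varied at the heteroaromatic amide and at the ether chain on the core. Compound 1 `COc1cc2nccc(Oc3ccc(NC(=O)c4ncc(-c5ccc(F)cc5)o4)cc3)c2cc1OC` gives 5590 nM in a functional assay on A549 cells (Homo sapiens) for antiproliferative activity, read by MTT assay, with a stated time of 72 h; on this read-out lower numbers stand for stronger inhibition and higher numbers for weaker inhibition. Compound 2 `COc1cc2c(Oc3ccc(NC(=O)c4nc(-c5ccc(F)cc5)no4)cc3)ccnc2cc1OCCCN1CCC(C)CC1` gives 870 nM in this assay, and compound 3 `COc1cc2c(Oc3ccc(NC(=O)c4nnc(-c5ccc(F)cc5)o4)cc3)ccnc2cc1OCCCN1CCC(C)CC1` gives 2730 nM. Compound 3 thus stands second highest of the three numbers, above compound 2 and below compound 1. For the measured compounds named here, the only single-point step recorded is a 3.1-fold higher number from compound 2 to compound 3 (0.50 log units; beyond the scatter), which concerns the heteroaromatic ring and not the chain. Compound 4 `COc1cc2nccc(Oc3ccc(NC(=O)c4nnc(-c5ccc(F)cc5)o4)cc3)c2cc1OC` differs from compound 3 by hydrogen in place of 2-(4-methylpiperidin-1-yl)ethyl on a saturated chain carbon bound to an oxygen on an aromatic ring. Going by the values given here, no measured pair isolates this chain change: compound 1 also carries the methoxy but differs from compound 3 in the heterocycle as well, so its higher number cannot be assigned to the chain alone. Among the compounds with values here, with no step bearing directly on the change, compound 4 is expected to give a somewhat higher number than compound 3, a step of a 1.6-fold higher number from compound 3 to compound 4 (0.22 log units; within the scatter) in this assay. The estimate for compound 4 is 4500 nM, with a range from 1500 nM to 14000 nM.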

Compound 4, half-maximal inhibitory concentration: 5140 nM
Compound 4: middle estimate off by 1.1-fold (0.06 log units), on the low side; the measured number falls inside the stated range.
By their numbers in this assay, from the lowest: compound 2; then compounds 3, 4 and 1 (each within the scatter of the next, the first and the last beyond it).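

In this assay, the exchange at this position shows a 1.9-fold higher number from compound 3 to compound 4 (0.27 log units; within the scatter) and so lies within the scatter: on the 5-(4-fluorophenyl)-1,3,4-oxadiazol-2-yl amide, the 3-(4-methylpiperidin-1-yl)propoxy and methoxy compounds cannot be told apart. With methoxy on the core, the heterocycle exchange gives a 1.1-fold lower number from compound 1 to compound 4 (0.04 log units; within the scatter) and also stays within the scatter, whereas the heterocycle exchange between the chain-bearing compounds gave a 3.1-fold higher number from compound 2 to compound 3 (0.50 log units; beyond the scatter) and lay beyond it. Nothing available gives a reason for these results.

On these data alone, whether the 3-(4-fluorophenyl)-1,2,4-oxadiazol-5-yl amide of compound 2 (870 nM) would keep its number with methoxy in place of the chain remains open. Also open, as far as these compounds go, is how a morpholine or a carboxylic acid at the end of the chain would compare with the 4-methylpiperidin-1-yl group.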